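This account rests on a few compounds, and the source may have more. Where it says the series, first, only, none or still open, it means among the compounds named here.

Compound 1, `Brc1cccc([C@@H]2C[C@@H]3Cc4ccc5ccccc5c4N2O3)c1`: in an ADME assay on Vero cells (Chlorocebus sabaeus) for cytotoxicity, read by MTT assay, with a stated time of 72 h (a higher number here means that more compound is tolerated, a lower number that less compound is tolerated), compound 1 gives > 250000 nM, which is a limit of the assay.
Compound 2, `COc1cccc([C@@H]2C[C@@H]3Cc4ccc5ccccc5c4N2O3)c1`: in this assay compound 2 gives > 300000 nM, also a limit.
Compound 3, `Cc1cccc([C@@H]2C[C@@H]3Cc4ccc5ccccc5c4N2O3)c1`: in this assay compound 3 gives > 300000 nM, again a limit.

Compound 3 thus stands among values that are all limits: the limit of > 250000 nM in this assay, at which 1 of the 3 values shown sits, and the limit of > 300000 nM in this assay, at which 2 of the 3 values shown sit, account for every value shown, so no compound can be ranked against another. Compound 4, `Clc1ccccc1[C@@H]1C[C@@H]2Cc3ccc4ccccc4c3N1O2`, differs from compound 3 by 2-chlorophenyl in place of 3-methylphenyl on a saturated ring carbon. The measured steps a step that the two limits leave unreadable from compound 1 to compound 2, a step that the two limits leave unreadable from compound 1 to compound 3 and a step that the two limits leave unreadable from compound 2 to compound 3 each exchange a group on an aromatic carbon of the same phenyl, and all are left unreadable by the limits. On this basis no step beyond the scatter is expected in this assay from compound 3 to compound 4, the estimated step being a number no higher from compound 3 to compound 4 (the limit leaves the size open). Compound 4 is expected to give about 300000 nM, within 150000 nM to 600000 nM, most likely reported once more only as a limit.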

Compound 4, half-maximal cytotoxic concentration: 37200 nM
For compound 4 the middle estimate is 8.1-fold (0.91 log units) above the measured one; the whole stated range lies above it.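

In this assay, the exchange of the aryl group on the saturated ring carbon next to the ring nitrogen gives the first readable changes: an at least 8.0-fold lower number from compound 3 to compound 4 (0.90 log units; beyond the scatter), an at least 8.0-fold lower number from compound 2 to compound 4 (0.90 log units; beyond the scatter) and an at least 6.7-fold lower number from compound 1 to compound 4 (0.82 log units; beyond the scatter), whereas the steps among compound 1, compound 2 and compound 3 cannot be read. The response at this position therefore depends on the aryl group, and 2-chlorophenyl gives compound 4 a number rather than a limit. Nothing shown explains this drop. Still open, going by these compounds, is whether the chlorine or its place on the phenyl carries the change, which 3-chlorophenyl would help separate. On these data alone, how an amine or a carboxylic acid on the phenyl would read also remains open.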